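The compounds below may be only part of what the source reports. "The series", "measured", "known", "first", "only" and "open" are said of these compounds alone.

Measured so far:
compound 1 `COc1cc2c(Nc3nc4ccc(C(=O)Nc5c(C)cccc5C)cc4s3)ncnc2cc1OCCCN1CCC(C)CC1`, in a functional assay on U-937 cells (Homo sapiens) for cytotoxicity, read by WST assay, with a stated time of 72 h (a lower number here means a stronger inhibitor, a higher number a weaker inhibitor), compound 1 gives 11200 nM
compound 2 `COc1cc2c(Nc3nc4ccc(C(=O)Nc5c(C)cccc5Cl)cc4s3)ncnc2cc1OCCCN1CCCCC1`, in this assay compound 2 gives 8600 nM

Among the measured compounds shown here, compound 1 and compound 2 differ at two places, so no single step between them is available; their two values lie within the scatter of each other and compound 2 does not separate from compound 1. Compound 3 `COc1cc2c(Nc3nc4ccc(C(=O)Nc5c(C)cccc5Cl)cc4s3)ncnc2cc1OCCCN1CCC(C)CC1` is not yet measured. From compound 2 it differs by methyl in place of hydrogen on a saturated ring carbon. For the measured compounds named here, no measured pair isolates this change. Compound 1 already carries the 4-methylpiperidin-1-yl group and its value of 11200 nM sits within scatter of compound 2, so no step beyond the scatter is expected. The expected step is a 1.0-fold higher number from compound 2 to compound 3 (0.02 log units; within the scatter). For compound 3 the estimate in this assay is 9000 nM, range 4000 nM to 20000 nM.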

Compound 3, half-maximal inhibitory concentration: 9200 nM
Beside the measured number, compound 3's estimate is 1.0-fold (0.01 log units) below it; measured number inside the range.
By their numbers in this assay, from the lowest: compounds 2, 3 and 1 (each within the scatter of the next).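

In this assay, the change from piperidin-1-yl to 4-methylpiperidin-1-yl on the shared core gives a 1.1-fold higher number from compound 2 to compound 3 (0.03 log units; within the scatter) and so does not separate methyl from hydrogen at this saturated ring carbon, three ring bonds from the ring nitrogen. Chloro in place of methyl on an aromatic carbon, now isolated, gives a 1.2-fold lower number from compound 1 to compound 3 (0.09 log units; within the scatter) and likewise does not separate the two groups. No evidence bearing on these two steps is available.

On these data alone, whether a carboxylic acid or a primary amine at this ring carbon would move the number beyond the scatter stays open. So does the effect of a morpholin-4-yl group in place of the piperidine ring.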